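A Methyl Group on the Ring of Compound 2

A few compounds are considered here, and "the series" means these few. Any claim that something is new, unique, unknown or untested is made for them only; others in the source may bear on it.

Compound 1 `O=C1CCCN1CC#CCn1cnc2ccccc21`: > 100 mg/kg
Compound 2 `CC(=O)N(C)C(C)C#CCn1ccnc1`: > 100 mg/kg
Compound 3 `CC(=O)N(C)C(C)C#CCn1cncc1C`: not yet measured

In a functional assay on the whole organism for antagonist activity, with Mus musculus as the target (a higher number here means that more compound is needed for the effect, a lower number that less compound is needed), compound 2 gives > 100 mg/kg, which is a limit of the assay and not a number. Both measured compounds rest at the limit of > 100 mg/kg in this assay, at which 2 of the 2 values shown sit. Compound 3 differs from compound 2 by methyl in place of hydrogen on an aromatic carbon. Within the data shown here, no measured step is available as a guide, so no change beyond the scatter is expected. The expected size of the change is a number no higher from compound 2 to compound 3 (the limit leaves the size open). For compound 3 the estimated dose is 100 mg/kg, within an expected range from 30 mg/kg to 200 mg/kg.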

Compound 3, dose for half-maximal effect: 80 mg/kg
For compound 3 the middle estimate is 1.3-fold (0.10 log units) above the measured one; the measured number falls inside the stated range.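

Among the compounds shown, only compound 3 gives a number rather than a limit of the assay in this assay, so this aromatic carbon, next to the ring atom that bears a large group, is where a change first yields a readable dose. Methyl in place of hydrogen here gives an at least 1.2-fold lower number from compound 2 to compound 3 (0.09 log units; that floor lies within the scatter), and its true size stays open. The other values remain limits of the assay: the limit of > 100 mg/kg in this assay, at which 2 of the 3 values shown sit.

Going by these compounds, whether an ethyl group or a chlorine atom on this carbon would move the dose remains open. So does whether methyl would act alike on the core of compound 1.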